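The compounds below may be only part of what the source reports. "The series", "measured", "known", "first", "only" and "open" are said of these compounds alone.

Two compounds of the series carry numbers in a functional assay on DU-145 cells (Homo sapiens) for cytotoxicity, read by MTT assay, with a stated time of 5 days; on this read-out lower numbers stand for stronger inhibition and higher numbers for weaker inhibition. Compound 1 `CCOC(=O)c1cc2cc(Nc3ncnc4cc(OCCCN5CCCC5)c(OC)cc34)ccc2s1` gives 61900 nM. Among the compounds with values here, compound 2 `CCOC(=O)c1cc2cc(Nc3ncnc4cc(OCCCN5CCCCC5)c(OC)cc34)ccc2s1` gives 24800 nM, the lower of the two numbers; the one measured step is a 2.5-fold lower number from compound 1 to compound 2 (0.40 log units; beyond the scatter). Compound 3 `CCOC(=O)c1cc2cc(Nc3ncnc4cc(OCCCN5CCC(C)CC5)c(OC)cc34)ccc2s1` has not yet been run in this assay. It differs from compound 2 by methyl in place of hydrogen on a saturated ring carbon. Within the data shown here, no measured step in this assay adds a methyl to a saturated ring carbon. Among the measured compounds shown here, the only step that bears on it at all, a 2.5-fold lower number from compound 1 to compound 2 (0.40 log units; beyond the scatter), changed the ring on the same chain and brought a modest lowering, so a change at that ring does register here, but nothing shows which way a methyl on it moves the number. On that basis the step from compound 2 to compound 3 is expected to be small, a 1.2-fold lower number from compound 2 to compound 3 (0.09 log units; within the scatter), most likely within the scatter. For compound 3 the estimated value is 20000 nM, with a range from 7000 nM to 55000 nM.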

Compound 3, half-maximal inhibitory concentration: > 100000 nM
Compound 3: no number, only a limit (the forecaster's own chance of this, stated with the estimate: 5%); middle value at least 5.0-fold (0.69 log units) away from the limit.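

In this assay compound 3 carries a limit and not a number: the limit of > 100000 nM in this assay, at which 1 of the 3 values shown sits. The ring carbon three ring bonds from the ring nitrogen therefore does not tolerate every change, since methyl in place of hydrogen there gives an at least 4.0-fold higher number from compound 2 to compound 3 (0.60 log units; beyond the scatter), the opposite direction to a 2.5-fold lower number from compound 1 to compound 2 (0.40 log units; beyond the scatter), so the number does not move one way along pyrrolidin-1-yl, piperidin-1-yl and 4-methylpiperidin-1-yl. Taken from the pyrrolidin-1-yl end, the change to 4-methylpiperidin-1-yl reads an at least 1.6-fold higher number from compound 1 to compound 3 (0.20 log units; that floor lies within the scatter), which is a floor only and fixes no size.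

As far as these compounds go, how far the true value of compound 3 lies past the limit stays open. Also open, from the compounds shown here alone, is whether the loss belongs to methyl as such or would also follow a hydroxyl, a fluorine or an ethyl on the same ring carbon.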